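A few compounds are considered here, and "the series" means these few. Any claim that something is new, unique, unknown or untested is made for them only; others in the source may bear on it.

Three closely related compounds have been measured in a physicochemical assay for solubility, in phosphate buffer, at pH 7.4; on this read-out higher numbers stand for higher solubility and lower numbers for lower solubility. Compound 1 (`O=C(Nc1ccc(C(F)(F)F)cc1)NC1CCN(C(=O)C2CC2)CC1`) gives 19.7 ug/mL, compound 2 (`CCC(C)C(=O)N1CCC(NC(=O)Nc2ccc(C(C)C)cc2)CC1`) gives 2.6 ug/mL, and compound 3 (`CCC(C)C(=O)N1CCC(NC(=O)Nc2ccc(C(C)(C)C)cc2)CC1`) gives 0.02 ug/mL, the lowest number of the three and beyond the scatter from both others. Compound 4 (`CCC(C)C(=O)N1CCC(NC(=O)Nc2ccc(C(F)(C(F)(F)F)C(F)(F)F)cc2)CC1`) has not yet been measured. It departs from compound 3 in a single place: 1,2,2,2-tetrafluoro-1-(trifluoromethyl)ethyl in place of tert-butyl on an aromatic carbon. In words, 1,2,2,2-tetrafluoro-1-(trifluoromethyl)ethyl stands in place of tert-butyl on an aromatic carbon.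

Among the compounds with values here, only one measured step bears directly on this group. That step is a 130-fold lower number from compound 2 to compound 3 (2.11 log units; beyond the scatter), where a methyl replaced a hydrogen, and it was large. It shows that a small edit at this place can move the number a long way, but it involves no fluorine. Compound 1 does carry a trifluoromethyl group, yet it differs from compound 3 elsewhere too, so the gap between them is no clean guide. The data therefore give only weak support for a direction. Since compound 3 already sits at 0.02 ug/mL, a moderate rise is expected rather than a further fall, and the uncertainty is wide. The expected change is a 5.0-fold higher number from compound 3 to compound 4 (0.70 log units; beyond the scatter). For compound 4 the estimated value is 0.1 ug/mL, with an expected range from 0.01 ug/mL to 1.5 ug/mL.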

Compound 4, solubility: 0.17 ug/mL
The estimate for compound 4 lay 1.7-fold (0.23 log units) below the measured number; measured number inside the range.
By their numbers in this assay, from the lowest: compound 3; then compound 4; then compound 2; then compound 1.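

In this assay, 1,2,2,2-tetrafluoro-1-(trifluoromethyl)ethyl in place of tert-butyl gives an 8.5-fold higher number from compound 3 to compound 4 (0.93 log units; beyond the scatter), so the earlier fall at this place on the aromatic ring is not a one-way street: a group of 10 heavy atoms, larger than the 4 of tert-butyl, gives a higher number, and here the number does not simply drop as the group grows. The recovery is only partial, however, since the same group in place of isopropyl gives a 15-fold lower number from compound 2 to compound 4 (1.18 log units; beyond the scatter), which leaves compound 4 between compound 3 and compound 2 in this series. The compounds show only that the numbers moved, and no measurement shown explains why this fluorinated group gives a higher number than tert-butyl.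

Still open, going by these compounds, is whether this rise belongs to fluorine or to some other difference between the two groups, which a single pair cannot separate. Also open, on these data alone, is how a quite different group at this place, such as an amine or a carboxylic acid, would move the number on the core shared by compound 2, compound 3 and compound 4.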